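The compounds below may be only part of what the source reports. "The series", "measured", "known", "first", "only" and "open" are said of these compounds alone.

Compound 1, `c1ccc(Cn2nnc3c(NC4CC4)nc(-c4ccccc4)nc32)cc1`, gives 11000000 nM in an assay on isolated protein for binding affinity to adenosine receptor A1 (Bos taurus); on this read-out higher numbers stand for weaker inhibition and lower numbers for stronger inhibition.
Compound 2, `OC1CCC(Nc2nc(-c3ccccc3)nc3c2nnn3Cc2ccccc2F)CC1`, gives 1850000 nM in this assay.
Compound 3, `FC(F)(F)c1ccccc1Cn1nnc2c(NC3CC3)nc(-c3ccccc3)nc21`, gives 7800000 nM in this assay.

Among these three numbers compound 1 stands highest. Its nearest neighbour is compound 3, reached by a 1.4-fold lower number from compound 1 to compound 3 (0.15 log units; within the scatter), a step that stays within the scatter. Compound 2 lies furthest away, and the gap between compound 1 and compound 2 is the only one among the three that goes beyond the scatter.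

Compound 4, `O[C@H]1CCCC[C@@H]1Nc1nc(-c2ccccc2)nc2c1nnn2Cc1ccccc1`, has not yet been measured in this assay. Compared with compound 1 the change is 2-hydroxycyclohexyl in place of cyclopropyl on a nitrogen on an aromatic ring.

Within the data shown here, no measured step alters the group on that nitrogen while leaving the rest untouched. The step from compound 1 to compound 3 changes a substituent on the aromatic carbon of the benzyl group and does not bear on the amine substituent. Compound 2 carries a hydroxycyclohexyl group on the same nitrogen but also a fluorine on the benzyl group, so what its value shows against compound 1 mixes two changes. On that comparison alone a lower number is expected, and the step of a 4.4-fold lower number from compound 1 to compound 4 (0.64 log units; beyond the scatter) is the estimate for compound 4. Compound 4 is therefore expected to give about 2500000 nM, with a range from 800000 nM to 8000000 nM.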

Compound 4, inhibition constant: 10300000 nM
Estimate against measurement, compound 4: 4.1-fold (0.61 log units) below; measured number outside the range, above it.
By their numbers in this assay, from the lowest: compound 2; then compounds 3, 4 and 1 (each within the scatter of the next).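

In this assay, replacing cyclopropyl with 2-hydroxycyclohexyl on a nitrogen on an aromatic ring, with the rest of the molecule untouched, gives a 1.1-fold lower number from compound 1 to compound 4 (0.03 log units; within the scatter) and so leaves compound 1 and compound 4 indistinguishable. The entering group brings a six-membered ring, a hydrogen-bond donor, a hydrogen-bond acceptor and 2 defined stereocentres, yet this exchange at this position produces no readable shift on the shared core, so a hydroxycyclohexyl group on this nitrogen cannot by itself be taken to account for the value of compound 2. No measurement at hand offers an explanation for this outcome.

The compounds shown leave open what does set apart compound 2, at 1850000 nM, since it carries a fluorine on the benzyl group and a different hydroxycyclohexyl group, and neither change is read alone. They also leave open how a plain cyclohexyl without the hydroxyl, a morpholine or an open alkyl chain on this nitrogen would compare with cyclopropyl.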